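The source may report more compounds than this note shows. Statements on the series, on what has been measured and on what is new or still open speak of the compounds shown alone.

Compound 1 `CCn1c(C(=O)NCCN)ccc1C(CC)(CC)c1ccc(OCS(=O)(=O)c2ccccc2)c(C)c1` gives 6470 nM in a functional assay on MCF7 cells (Homo sapiens) for antiproliferative activity, read by MTT assay, with a stated time of 24 h (a lower number here means a stronger inhibitor, a higher number a weaker inhibitor), the lowest of the two numbers in this small set. Compound 2 `CCn1c(C(=O)NC2(CO)CC2)ccc1C(CC)(CC)c1ccc(OCS(=O)(=O)c2ccccc2)c(C)c1` gives 28800 nM, the step being a 4.5-fold higher number from compound 1 to compound 2 (0.65 log units; beyond the scatter). Compound 3 `CCn1c(C(=O)N[C@@H](CC(=O)O)C(=O)O)ccc1C(CC)(CC)c1ccc(OCS(=O)(=O)c2ccccc2)c(C)c1` gives only a limit of this assay, > 50000 nM, which is the limit of > 50000 nM in this assay, at which 1 of the 3 values shown sits. The resulting steps are an at least 7.7-fold higher number from compound 1 to compound 3 (0.88 log units; beyond the scatter) and an at least 1.7-fold higher number from compound 2 to compound 3 (0.23 log units; that floor lies within the scatter). Compound 4 `CCn1c(C(=O)N[C@H](CCC(=O)O)C(=O)O)ccc1C(CC)(CC)c1ccc(OCS(=O)(=O)c2ccccc2)c(C)c1` differs from compound 1 by 1,3-dicarboxypropyl in place of 2-aminoethyl on an amide-type nitrogen. The nearest measured step is an at least 7.7-fold higher number from compound 1 to compound 3 (0.88 log units; beyond the scatter); a step of similar size and in the same direction is therefore expected in this assay, with a fair chance that only the limit is reported again. For compound 4 the estimate is 50000 nM (range 20000 nM to 150000 nM), which would be an expected 7.7-fold higher number from compound 1 to compound 4 (0.89 log units; beyond the scatter).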

Compound 4, half-maximal inhibitory concentration: > 50000 nM
Compound 4: only a limit was reported; the forecaster's own chance of this, stated with the estimate: 60%; the middle value lies on the limit itself.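

Compound 4 also returns only a limit in this assay, so a second dicarboxy group on the amide-type nitrogen ends at the same ceiling: the limit of > 50000 nM in this assay, at which 2 of the 4 values shown sit.

Replacing 2-aminoethyl gives an at least 7.7-fold higher number from compound 1 to compound 4 (0.88 log units; beyond the scatter), while replacing 1-(hydroxymethyl)cyclopropyl gives an at least 1.7-fold higher number from compound 2 to compound 4 (0.23 log units; that floor lies within the scatter), so no order against compound 2 can be read. The step between compound 3 and compound 4 cannot be read, leaving the difference between 1,2-dicarboxyethyl and 1,3-dicarboxypropyl unresolved.

The compounds shown leave open whether a longer amine chain, such as 3-aminopropyl, would keep the level of compound 1. Also open, from the compounds shown here alone, is how a single carboxylic acid, such as carboxymethyl, would compare.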